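Methoxy for Chloro: an Estimate for Compound 4

The compounds below may be only part of what the source reports. "The series", "measured", "known", "first", "only" and "open" are said of these compounds alone.

Compound 1, `COc1c(/C=C2/C(=O)Nc3ccc(Cl)cc32)c2ccccc2n1-c1ccccc1`: 5250 nM
Compound 2, `COc1cc2c(/C=C3/C(=O)Nc4ccc(O)cc43)c(Cl)n(Cc3cc(OC)c(OC)c(OC)c3)c2cc1C`: 2040 nM
Compound 3, `COc1cc2c(cc1C)NC(=O)/C2=C/c1c(Cl)n(Cc2cc(OC)c(OC)c(OC)c2)c2cc(C)c(OC)cc12`: 49000 nM

All three compounds were tested in a functional assay on cells (Cancer cell lines, Homo sapiens) for cytotoxicity, with a stated time of 48 h; a lower number here means a stronger inhibitor of growth, a higher number a weaker inhibitor of growth. Compound 1 stands second highest of the three numbers: compound 2 sits lower by a gap beyond the scatter, and compound 3 sits higher by a gap beyond the scatter. Among the measured compounds shown here, no pair of measured compounds differs in a single place, so no measured step exists. Compound 4, `COc1ccc2c(c1)/C(=C\c1c(OC)n(-c3ccccc3)c3ccccc13)C(=O)N2`, differs from compound 1 in one place: methoxy in place of chloro on an aromatic carbon. With nothing measured that shares this change, a step from compound 1 to compound 4 of no more than the scatter is expected, a 1.1-fold higher number from compound 1 to compound 4 (0.06 log units; within the scatter). Compound 4 is therefore estimated at 6000 nM, in a range from 2000 nM to 18000 nM.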

Compound 4, concentration for 50% growth inhibition: 980 nM
For compound 4 the middle estimate is 6.1-fold (0.79 log units) above the measured one; measured number below the stated range.
By their numbers in this assay, from the lowest: compound 4; then compound 2; then compound 1; then compound 3.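

In this assay, among the compounds shown here, methoxy in place of chloro on an aromatic carbon gives a 5.4-fold lower number from compound 1 to compound 4 (0.73 log units; beyond the scatter), the only single-place step measured here. It shows that this position, on the six-membered aromatic ring of carbon only, is not indifferent to which group it carries. Nothing measured here explains the step.

The compounds shown leave open whether an amine or a carboxylic acid at this position would lower the number further or raise it. They also leave open whether the same change would give a similar step on the cores of compound 2 and compound 3.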